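This account rests on a few compounds, and the source may have more. Where it says the series, first, only, none or still open, it means among the compounds named here.

Measured in a functional assay on KBVIN cells (Homo sapiens) for antiproliferative activity, read by sulforhodamine B assay, with a stated time of 3 days; a higher number here means that more compound is needed for the effect, a lower number that less compound is needed:
compound 1 `CCC1=C(O)c2c(oc(-c3ccc(SC)cc3)cc2=O)C(CC)(CC)C1=O` gives 1.38 uM;
compound 2 `CCC1=C(O)c2c(oc(-c3cccc(OC)c3)cc2=O)C(CC)(CC)C1=O` gives 1.22 uM;
compound 3 `CCC1=C(O)c2c(oc(-c3ccc(OC)c(Cl)c3)cc2=O)C(CC)(CC)C1=O` gives 1.37 uM.

Compound 1 stands at the top of these three numbers, but a 1.0-fold lower number from compound 1 to compound 3 (0.00 log units; within the scatter) and a 1.1-fold lower number from compound 1 to compound 2 (0.05 log units; within the scatter) both lie within the scatter, so the three compounds are not separated. The unmeasured compound 4 `CCC1=C(O)c2c(oc(-c3cc(C)c(O)c(C)c3)cc2=O)C(CC)(CC)C1=O` differs from compound 1 by 4-hydroxy-3,5-dimethylphenyl in place of 4-(methylsulfanyl)phenyl on an aromatic carbon. Going by the values given here, the steps that bear on this are the exchanges of the same aryl group among compounds 1, 2 and 3: a 1.1-fold lower number from compound 1 to compound 2 (0.05 log units; within the scatter), a 1.0-fold lower number from compound 1 to compound 3 (0.00 log units; within the scatter) and a 1.1-fold higher number from compound 2 to compound 3 (0.05 log units; within the scatter), none beyond the scatter. A change of the aryl group is therefore expected to leave this assay essentially where it is, with no step beyond the scatter in either direction, as a 1.1-fold higher number from compound 1 to compound 4 (0.04 log units; within the scatter). Compound 4 is estimated at 1.5 uM, within 0.6 uM to 4 uM.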

Compound 4, concentration for half-maximal effect: 8.9 uM
Compound 4: the middle estimate sits 5.9-fold (0.77 log units) below what was measured, and the stated range ends below it.
By their numbers in this assay, from the lowest: compounds 2, 3 and 1 (each within the scatter of the next); then compound 4.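

Within this assay this position is not indifferent to the aryl group, as the earlier exchanges among compounds 1, 2 and 3 had suggested: 4-hydroxy-3,5-dimethylphenyl brings (a 6.4-fold higher number from compound 1 to compound 4 (0.81 log units; beyond the scatter)) and (a 6.5-fold higher number from compound 3 to compound 4 (0.81 log units; beyond the scatter)) and (a 7.3-fold higher number from compound 2 to compound 4 (0.86 log units; beyond the scatter)). Compound 4 is also the only one shown whose aryl group has a hydrogen-bond donor. Nothing available explains this step.

Whether the hydroxyl or the two methyl groups account for it stays open, as the change brings both together. On these data alone, how an aryl group carrying an amine or a carboxylic acid would stand also remains unknown.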